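Two Amides Compared: a Branched Chain Gives Way to an Oxetane

The compounds below may be only part of what the source reports. "The series", "measured", "known", "first", "only" and "open" are said of these compounds alone.

Going by the values given here, the three compounds measured so far share a common core and differ in the groups around it. In an ADME assay on HEK293 cells for agonist activity at metabotropic glutamate receptor 5 (Rattus norvegicus), read by fluorescence and calcium flux (on this read-out higher numbers stand for larger maximal responses and lower numbers for smaller maximal responses), compound 1 `C[C@@H](NC(=O)c1ccc(C#Cc2cccc(F)c2)cc1)C(C)(C)O` gives 43.6%, compound 2 `C[C@@H](NC(=O)c1ccc(C#Cc2cccc(F)c2)nc1)C(C)(C)O` gives 26.6%, and compound 3 `C[C@H](NC(=O)c1ccc(C#Cc2cccc(F)c2)cn1)C(C)(C)C` gives 20%. Compound 3 stands lowest of the three; its gap to compound 2 lies within the usual scatter, while its gap to compound 1 lies beyond it. Compound 4 `CC1(CCNC(=O)c2ccc(C#Cc3cccc(F)c3)cn2)COC1` has not yet been measured. It differs from compound 3 in one place: 2-(3-methyloxetan-3-yl)ethyl in place of 1,2,2-trimethylpropyl on an amide-type nitrogen. Among the compounds with values here, no step between measured compounds covers this exchange, so in this assay a step of small size, not beyond the scatter, is expected in either direction. For compound 4 the expected value is 22%, within a range from 8% to 40%. This corresponds to an expected step of a number 2 percentage points higher from compound 3 to compound 4 (within the scatter).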

Compound 4, largest response reached (reported as efficacy), in percent of the reference or control that the assay uses: 16.3%
For compound 4 the middle estimate is 5.7 percentage points above the measured one; measured number inside the range.
By their numbers in this assay, from the lowest: compounds 4, 3 and 2 (each within the scatter of the next, the first and the last beyond it); then compound 1.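

In this assay, 2-(3-methyloxetan-3-yl)ethyl in place of 1,2,2-trimethylpropyl on an amide-type nitrogen gives a number 3.7 percentage points lower from compound 3 to compound 4 (within the scatter). At this nitrogen, then, the group can take up a four-membered ring holding an oxygen and lose its defined stereocentre without the maximal response shifting beyond the usual scatter. Nothing measured here speaks to the reason for this result. From the compounds shown here alone, whether a primary amine or a carboxylic acid on this chain would leave the response similarly unmoved stays open, as does whether 2-(3-methyloxetan-3-yl)ethyl would behave alike on the core of compound 1.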